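This account rests on a few compounds, and the source may have more. Where it says the series, first, only, none or still open, it means among the compounds named here.

Of the compounds shown here, two have been tested in a functional assay on HepG2 cells (Homo sapiens) for antiproliferative activity, tested at 1 uM; a lower number here means less inhibition, a higher number more inhibition at the concentration tested (going by the name of the read-out). Compound 1, with the structure `COc1ccc(CO/N=C/c2c(C)nn(C)c2Oc2ccc(Cl)cc2)cc1`, gives 13.9%. Compound 2, with the structure `Cc1ccc(CO/N=C/c2c(C)nn(C)c2Oc2ccc(Cl)cc2)cc1`, gives 31.3%. Within the data shown here, the only measured step, a number 17.4 percentage points higher from compound 1 to compound 2 (beyond the scatter), comes with methyl in place of methoxy on an aromatic carbon. Among the two numbers compound 2 stands highest, and its nearest neighbour is compound 1, which lies beyond the scatter below it.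

Compound 3, with the structure `CCOC(=O)c1ccc(CO/N=C/c2c(C)nn(C)c2Oc2ccc(Cl)cc2)cc1`, has not yet been measured. Its change from compound 2 is this: ethoxycarbonyl in place of methyl on an aromatic carbon. Among the measured compounds shown here, the one measured step concerns the same aromatic carbon, but it exchanged methoxy for methyl, and it was modest. For the measured compounds named here, no measured step exchanges methyl for ethoxycarbonyl, so nothing in the data points firmly in either direction for this assay. The expectation is therefore a step of about a number 6.3 percentage points lower from compound 2 to compound 3 (within the scatter), which stays within the scatter. Compound 3 is estimated to give 25% in this assay, with a range from 8% to 45%.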

Compound 3, a percentage reported as inhibition, at one concentration (the size of the read-out at that concentration, not a potency): 27.4%
Estimate against measurement, compound 3: 2.4 percentage points below; measured number inside the range.
By their numbers in this assay, from the lowest: compound 1; then compounds 3 and 2 (each within the scatter of the next).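

In this assay, replacing methyl with the much larger ethoxycarbonyl, on the aromatic carbon para to a large group, gives a number 3.9 percentage points lower from compound 2 to compound 3 (within the scatter), so this change of 1 heavy atom for 5, with 2 hydrogen-bond acceptors added, cannot be told apart from no change at this position. Among these compounds, the same position also gives a number 13.5 percentage points higher from compound 1 to compound 3 (beyond the scatter), so methoxy is now the one group of the three that stands apart, and the read-out does not simply follow the size of the group, since methoxy, in size between the other two, gives the lowest number. No measurement shown here bears on why methoxy differs from the other two groups.

Going by these compounds, it remains open what a carboxylic acid, an amine or a longer ester chain at this carbon would do, and whether any of these would lift the number clear of compound 2 and compound 3. On these data alone, because this assay reports inhibition at a single concentration, how compound 2 and compound 3 compare across a range of concentrations also remains open.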